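Swapping an Ethylsulfanyl Tail for Dimethylamino

The source may report more compounds than this note shows. Statements on the series, on what has been measured and on what is new or still open speak of the compounds shown alone.

Compound 1, `CN(C)S(=O)(=O)CCn1c(=N)sc2cc(OC(F)(F)F)ccc21`, gives in a functional assay on the whole organism with Rattus norvegicus as the target (a higher number here means that more compound is needed for the effect, a lower number that less compound is needed), only a limit of the assay, > 10 mg/kg.
Compound 2, `CCSCCn1c(=N)sc2cc(OC(F)(F)F)ccc21`, gives in this assay a value of 2.2 mg/kg.

Compound 2 holds the only real number shown; the other value is a limit. Within the data shown here, the one measured step, an at least 4.5-fold lower number from compound 1 to compound 2 (0.65 log units; beyond the scatter), rests on (the limit of > 10 mg/kg in this assay, at which 1 of the 2 values shown sits), so its true size is not known beyond being at least modest. Compound 3, `CN(C)CCn1c(=N)sc2cc(OC(F)(F)F)ccc21`, differs from compound 2 by dimethylamino in place of ethylsulfanyl on a saturated chain carbon, two bonds along the chain from an aromatic nitrogen. Among the measured compounds shown here, no measured step covers this change: the step to compound 2 exchanged a different group at the same place. The expectation for compound 3 in this assay is therefore anchored on compound 2 with wide uncertainty. Compound 3 is estimated at 3 mg/kg, with a range from 0.8 mg/kg to 10 mg/kg, meaning an expected step of a 1.4-fold higher number from compound 2 to compound 3 (0.13 log units; within the scatter).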

Compound 3, dose for half-maximal effect: 2.3 mg/kg
For compound 3 the middle estimate is 1.3-fold (0.12 log units) above the measured one, within the range that was stated.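

In this assay, sulfur and nitrogen tails of the same heavy-atom count prove interchangeable at this place on the chain, a saturated chain carbon two bonds along from an aromatic nitrogen: the swap gives a 1.0-fold higher number from compound 2 to compound 3 (0.02 log units; within the scatter). Dimethylamino in place of dimethylsulfamoyl gives an at least 4.3-fold lower number from compound 1 to compound 3 (0.63 log units; beyond the scatter), so of the three tails shown, compound 1 is the one that stands apart, while compound 2 and compound 3 cannot be told apart. The true size of that second step remains unknown, since compound 1 gives > 10 mg/kg, which is a limit of the assay and not a number: the limit of > 10 mg/kg in this assay, at which 1 of the 3 values shown sits.

The compounds shown leave open how far this interchangeability extends, for instance to a piperidine or a carboxylic acid at the same place. They also leave open whether a 3-(dimethylamino)propyl chain, one carbon longer, would keep the effect.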